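A few compounds are considered here, and "the series" means these few. Any claim that something is new, unique, unknown or untested is made for them only; others in the source may bear on it.

Of the compounds shown here, two have been tested in a functional assay on HeLa cells (Homo sapiens) for cytotoxicity, read by MTT assay, with a stated time of 24 h; on this read-out lower numbers stand for stronger inhibition and higher numbers for weaker inhibition. For the measured compounds named here, compound 1, `C=CC1=C(C(=O)NCc2ccc(C)cc2)C(c2ccc(OC)cc2)OC1`, is the only one of the pair with a numeric result: in this assay compound 1 gives 15900 nM. Compound 2, `C=CC1=C(C(=O)NCCC)C(c2ccc(F)cc2)OC1`, stands at the limit of the assay rather than at a number. In this assay compound 2 gives > 100000 nM, which is a limit and not a measured value, as the limit of > 100000 nM in this assay, at which 1 of the 2 values shown sits, records. Compound 1 and compound 2 differ in two places, so the two values show only that one of them lies at the limit and the other within the measured range.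

Compound 3, `C=CC1=C(C(=O)NCCC)C(c2ccc(OC)cc2)OC1`, is the next compound to be measured in this assay. Its difference from compound 2 is methoxy in place of fluoro on an aromatic carbon, on an aromatic carbon of a six-membered aromatic ring of carbon only, para to a large group. Because compound 2 sits at > 100000 nM, the step to compound 3 cannot be fixed from the data; the expected step of an at least 1.2-fold lower number from compound 2 to compound 3 (0.09 log units; that floor lies within the scatter) is a modest move toward lower numbers, with a real chance that compound 3 also stays at the limit. Compound 3 is therefore estimated at 80000 nM, within a range from 30000 nM to 300000 nM.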

Compound 3, half-maximal inhibitory concentration: 14000 nM
Beside the measured number, compound 3's estimate is 5.7-fold (0.76 log units) above it; the whole stated range lies above it.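

On the aromatic carbon para to a large group, with the rest of the molecule held the same, methoxy in place of fluoro gives an at least 7.1-fold lower number from compound 2 to compound 3 (0.85 log units; beyond the scatter) in this assay and brings the compound from the limit into the measured range. With methoxy kept on that carbon, ethyl in place of 4-methylphenyl on a saturated chain carbon bound to an amide-type nitrogen gives a 1.1-fold lower number from compound 1 to compound 3 (0.06 log units; within the scatter) and so leaves compound 1 and compound 3 indistinguishable in this assay despite the change in that chain. The first of these steps has a floor but no fixed size because compound 2 carries a limit and not a number: the limit of > 100000 nM in this assay, at which 1 of the 3 values shown sits.

The compounds shown leave open whether a chlorine, a methyl or an ethoxy on that aromatic carbon would read like methoxy or like fluoro. They also leave open whether the exchange of fluoro for methoxy gives a step of similar size with 4-methylphenyl on the chain, and how a longer chain or a carboxylic acid in that place would read.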